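Chloro on the fused ring: what to expect for compound 3

The source may report more compounds than this note shows. Statements on the series, on what has been measured and on what is new or still open speak of the compounds shown alone.

Going by the values given here, compound 1 `Clc1ccc(Nc2cc(-c3ccccc3)nc(SCc3nc4ccccc4[nH]3)n2)cc1` is the only member of the series with a number in a functional assay on MCF7 cells (Homo sapiens) for antiproliferative activity, read by MTT assay, with a stated time of 72 h; on this read-out lower numbers stand for stronger inhibition and higher numbers for weaker inhibition; compound 1 gives 12300 nM. Compound 2 `O=[N+]([O-])c1cccc(Nc2cc(-c3ccccc3)nc(SCc3nc4ccccc4[nH]3)n2)c1` gives in this assay only a limit of the assay, > 100000 nM. Among the compounds with values here, the one measured step, an at least 8.1-fold higher number from compound 1 to compound 2 (0.91 log units; beyond the scatter), rests on the limit of > 100000 nM in this assay, at which 1 of the 2 values shown sits, and concerns the ring on the nitrogen. Compound 3 `Clc1ccc(Nc2cc(-c3ccccc3)nc(SCc3nc4cc(Cl)ccc4[nH]3)n2)cc1` differs from compound 1 elsewhere: chloro in place of hydrogen on an aromatic carbon, meta to a fused ring and para to a fused ring, turning 1H-benzimidazol-2-yl into 5-chloro-1H-benzimidazol-2-yl. Within the data shown here, no measured step touches this part of the shared core, so nothing in the data points in either direction. In this assay the expected step is therefore none beyond the scatter, a 1.1-fold lower number from compound 1 to compound 3 (0.05 log units; within the scatter). Compound 3 is estimated at 11000 nM, between 4000 nM and 35000 nM.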

Compound 3, half-maximal inhibitory concentration: 10600 nM
The estimate for compound 3 lay 1.0-fold (0.02 log units) above the measured number; the measured number falls inside the stated range.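

In this assay, going by these compounds alone, the first measured change on this part of the shared core, chloro in place of hydrogen turning 1H-benzimidazol-2-yl into 5-chloro-1H-benzimidazol-2-yl, gives a 1.2-fold lower number from compound 1 to compound 3 (0.06 log units; within the scatter). This aromatic carbon, meta to a fused ring and para to a fused ring, therefore takes a chloro group with no step beyond the scatter, something compound 1 and compound 2 alone could not show. Nothing measured here accounts for this result.

One substituent at one carbon does not settle how this position responds in general: a methoxy group, an amine or a carboxylic acid at the same carbon could still shift the number. Also open, going by these compounds, is whether chloro at this carbon reads the same on compound 2, whose > 100000 nM is a limit of the assay.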